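Swapping a Pyridine for a Bromophenyl on the Five-Membered Ring

The source may report more compounds than this note shows. Statements on the series, on what has been measured and on what is new or still open speak of the compounds shown alone.

Compound 2 `O=C(Nc1cc2cc[nH]c(=O)c2cc1Cl)C1CNCC1c1ccccn1` was tested in a functional assay on aorta (Rattus norvegicus) for inhibition (on this read-out lower numbers stand for stronger inhibition and higher numbers for weaker inhibition), and gives 210 nM. Among the two numbers available it is the higher one; the only other measured compound, compound 3 `O=C(Nc1cc2cc[nH]c(=O)c2cc1Cl)C1CNCCC1c1ccccc1`, gives 55 nM in this assay, a gap that lies beyond the scatter of the method. Compound 1 `O=C(Nc1cc2cc[nH]c(=O)c2cc1Cl)C1(c2ccccc2)CCNC1` shares the core but in this assay compound 1 has only "not determined" (no result reported). Compound 4 `O=C(Nc1cc2cc[nH]c(=O)c2cc1Cl)C1CNCC1c1cccc(Br)c1` differs from compound 2 in one place: 3-bromophenyl in place of pyridin-2-yl on a saturated ring carbon. Among the compounds with values here, no measured pair tracks this exact change, so the expected step of a 1.8-fold lower number from compound 2 to compound 4 (0.24 log units; within the scatter) is a guess of a modest move toward stronger inhibition, with wide uncertainty. Compound 4 is therefore expected to give about 120 nM in this assay, plausibly anywhere from 35 nM to 450 nM.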

Compound 4, half-maximal inhibitory concentration: 63 nM
Compound 4: the middle estimate sits 1.9-fold (0.28 log units) above what was measured, and the stated range covers the measured number.
By their numbers in this assay, from the lowest: compounds 3 and 4 (each within the scatter of the next); then compound 2.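

In this assay, 3-bromophenyl in place of pyridin-2-yl on a saturated ring carbon gives stronger inhibition, and the step lies beyond the usual scatter (a 3.3-fold lower number from compound 2 to compound 4 (0.52 log units; beyond the scatter)). Within the data shown here, this is the first pair differing in one place, so it is the first direct sign that the aromatic group on this carbon of the five-membered ring affects the result. No measurement here explains this step.

On these data alone, the swap adds a bromine and removes the pyridine nitrogen together, so their separate contributions remain unknown. A 3-chlorophenyl or 3-methoxyphenyl group on this carbon would be the natural next comparison.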